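The source may hold more compounds than are shown below. What is called first, only, known or untested is meant among the compounds shown, and "the series" means these compounds.

Measured in an ADME assay on microsomes from liver (Rattus norvegicus) for metabolic stability, read by LC-MS, using NADPH, with a stated time of 10 min, tested at 0.1 uM; a lower number here means slower removal, a higher number faster removal of the compound:
compound 1 `COc1ccc(F)cc1N1C(=O)CSC1c1cccc(C(=O)NCCCCn2cccn2)c1`: 1470 mL.min-1.g-1
compound 2 `COc1ccc(F)cc1N1C(=O)CSC1c1cccc(C(=O)NCCCCc2ccccc2)c1`: 2300 mL.min-1.g-1
compound 3 `C#Cc1cccc(N2C(=O)CSC2c2cccc(C(=O)NCCCCc3ccccc3)c2)c1`: 1820 mL.min-1.g-1

The three values lie within the usual scatter of one another, so compound 1 does not stand apart from compound 2 or compound 3. Compound 4 `O=C(NCCCCn1cccn1)c1cccc(C2SCC(=O)N2c2cc(F)ccn2)c1` differs from compound 1 in one place: 4-fluoropyridin-2-yl in place of 5-fluoro-2-methoxyphenyl on an amide-type nitrogen in a ring. Among the measured compounds shown here, the only measured step at that place, made with other groups, is a 1.3-fold lower number from compound 2 to compound 3 (0.10 log units; within the scatter). The step on the chain, a 1.6-fold higher number from compound 1 to compound 2 (0.19 log units; within the scatter), is also small. Neither gives grounds for a step beyond the scatter in this assay, and none is expected. The estimated step is a 1.4-fold lower number from compound 1 to compound 4 (0.15 log units; within the scatter). Compound 4 is expected at 1050 mL.min-1.g-1, with an estimated range from 450 mL.min-1.g-1 to 2000 mL.min-1.g-1.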

Compound 4, intrinsic clearance in microsomes: 1200 mL.min-1.g-1
Compound 4: middle estimate off by 1.1-fold (0.06 log units), on the low side; low and high end bracket the measured number.
By their numbers in this assay, from the lowest: compounds 4, 1, 3 and 2 (each within the scatter of the next).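

At this place the step is a 1.2-fold lower number from compound 1 to compound 4 (0.09 log units; within the scatter), read in this assay. The earlier step at this place, a 1.3-fold lower number from compound 2 to compound 3 (0.10 log units; within the scatter), came with the phenyl chain and a carbon-only aromatic ring on both sides; this one holds the 1H-pyrazol-1-yl chain and brings in a ring with a hetero atom, and it too stays within the scatter. Nothing shown bears on why the number stays within the scatter. As far as these compounds go, whether an amine or a carboxylic acid at this place, or a longer chain bearing the 1H-pyrazol-1-yl group, would move the number beyond the scatter stays open.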